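The compounds below may be only part of what the source reports. "The series", "measured", "known", "first", "only" and "open" are said of these compounds alone.

Three compounds share one core and differ only in the group attached to the carbonyl carbon of an amide. Compound 1 `O=C(Nc1nc(-c2ccccc2)nc2c1nnn2Cc1ccccc1)C1CCCCC1` carries a cyclohexyl there, and in an assay (strain Wistar) for displacement of a labelled ligand from adenosine receptor A1 (Rattus norvegicus), read by scintillation counting (a higher number here means a weaker inhibitor, a lower number a stronger inhibitor), compound 1 gives 12 nM. Compound 2 `O=C(Nc1nc(-c2ccccc2)nc2c1nnn2Cc1ccccc1)c1ccoc1` carries a furan-3-yl, and in this assay compound 2 gives 10 nM. Compound 3 `O=C(Nc1nc(-c2ccccc2)nc2c1nnn2Cc1ccccc1)c1cccc(F)c1` carries a 3-fluorophenyl, and in this assay compound 3 gives 22 nM, separated from compound 1 by a 1.8-fold higher number from compound 1 to compound 3 (0.26 log units; within the scatter) and from compound 2 by a 2.2-fold higher number from compound 2 to compound 3 (0.34 log units; beyond the scatter).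

Compound 4 `O=C(Nc1nc(-c2ccccc2)nc2c1nnn2Cc1ccccc1)c1ccc(Cl)cc1` takes the next step: 4-chlorophenyl in place of 3-fluorophenyl on a carbonyl carbon. Both measured changes at this carbonyl carbon bear on it, since each swaps one group for another in the same place, and both were small. Swapping the ring again, with a chlorine in place of a fluorine, is therefore expected to move this assay little, with no clear direction. Compound 4 is expected to give about 20 nM, in a range from 8 nM to 50 nM. That estimate means a step of a 1.1-fold lower number from compound 3 to compound 4 (0.04 log units; within the scatter), expected to stay within the scatter.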

Compound 4, inhibition constant: 108 nM
Beside the measured number, compound 4's estimate is 5.4-fold (0.73 log units) below it; measured number above the stated range.
By their numbers in this assay, from the lowest: compounds 2, 1 and 3 (each within the scatter of the next, the first and the last beyond it); then compound 4.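

This position is less forgiving than the first three compounds suggested: the change to 4-chlorophenyl gives a 4.9-fold higher number from compound 3 to compound 4 (0.69 log units; beyond the scatter) in this assay, a larger step than any among the cyclohexyl, furan-3-yl and 3-fluorophenyl amides. Compound 4 also stands apart from the other two, with an 11-fold higher number from compound 2 to compound 4 (1.03 log units; beyond the scatter) and a 9.0-fold higher number from compound 1 to compound 4 (0.95 log units; beyond the scatter), so an aromatic ring on this carbonyl carbon is not enough on its own to predict the result. Nothing measured here accounts for the loss.

This step changes both the halogen and its place on the ring, so the compounds shown cannot tell which of the two matters. A 3-chlorophenyl or a 4-fluorophenyl would separate them, while a 4-methoxyphenyl would show whether other groups at that ring position behave like the chlorine.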